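The source may report more compounds than this note shows. Statements on the series, on what has been measured and on what is new or still open speak of the compounds shown alone.

Compound 1, `N#CC1=C(N)N(c2ccc(S(N)(=O)=O)cc2)C2=C(C(=O)CCC2)C1c1ccc(Cl)cc1Cl`: 95%
Compound 2, `CC(Cl)CC(=O)NC1=C(C#N)C(c2ccc(Cl)cc2Cl)C2=C(CCCC2=O)N1c1ccc(S(N)(=O)=O)cc1`: 60%

In a functional assay on Ehrlich cells (Mus musculus) for cytotoxicity, read by trypan blue exclusion, with a stated time of 2 h, tested at 100 ug/mL (a higher number here means a stronger effect of the compound at the concentration tested, a lower number a weaker effect), compound 1 gives 95%, while compound 2 gives 60%, the lower of the two numbers. Among the measured compounds shown here, the only measured step is a number 35 percentage points lower from compound 1 to compound 2 (beyond the scatter), which arises from (2-chloropropyl)carbonyl in place of hydrogen on an amine nitrogen. Compound 3, `N#CC1=C(NC(=O)C2CC2)N(c2ccc(S(N)(=O)=O)cc2)C2=C(C(=O)CCC2)C1c1ccc(Cl)cc1Cl`, differs from compound 2 by cyclopropyl in place of 2-chloropropyl on a carbonyl carbon. For the measured compounds named here, no measured step concerns an exchange within the acyl group itself, so that step is only a weak guide. The expected step is therefore no change at the digits printed from compound 2 to compound 3 (within the scatter), none beyond the scatter. Compound 3 is estimated at 60%, between 40% and 80%.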

Compound 3, a percentage reported as activity, at one concentration (the size of the read-out at that concentration, not a potency): 60%
Estimate against measurement, compound 3: no gap at the digits printed; the range from low to high includes it.
By their numbers in this assay, from the lowest: compounds 2 and 3 (each within the scatter of the next); then compound 1.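

In this assay there is no change at the digits printed from compound 2 to compound 3 (within the scatter) when cyclopropyl replaces 2-chloropropyl on a carbonyl carbon, so these two groups read alike at this place. With cyclopropylcarbonyl in place of hydrogen on the amine nitrogen there is also a number 35 percentage points lower from compound 1 to compound 3 (beyond the scatter) and so the drop is not tied to 2-chloropropyl alone. No measurement shown here bears on the reason for this result. From the compounds shown here alone, whether a longer chain, or a chain ending in an amine or a carboxylic acid, on that carbonyl carbon would read the same remains open.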